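Pyrazole amide isomers on the shared thienopyran core

The source may report more compounds than this note shows. Statements on the series, on what has been measured and on what is new or still open speak of the compounds shown alone.

Measured so far:
compound 1 `CC1(C)Cc2c(sc(NC(=O)[C@H](O)C(C)(C)C)c2C(N)=O)C(C)(C)O1` in an assay on cells for positive allosteric modulation of Cystic fibrosis transmembrane conductance regulator variant G551D (Homo sapiens), with stated times of 10 min and 2 min, in the presence of a further agent that is not named here; on this read-out higher numbers stand for an effect only at larger amounts of compound and lower numbers for an effect already at smaller amounts: 7780 nM
compound 2 `Cc1cn[nH]c1C(=O)Nc1sc2c(c1C(N)=O)CC(C)(C)OC2(C)C` in this assay: 123 nM

Among the measured compounds shown here, compound 2 holds the lowest of the two numbers in this assay; its only neighbour is compound 1, and the step of a 63-fold lower number from compound 1 to compound 2 (1.80 log units; beyond the scatter) is large and well beyond the scatter.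

Compound 3 `Cc1cc(C(=O)Nc2sc3c(c2C(N)=O)CC(C)(C)OC3(C)C)[nH]n1` is the next member to be measured. It differs from compound 2 by 3-methyl-1H-pyrazol-5-yl in place of 4-methyl-1H-pyrazol-5-yl on a carbonyl carbon; the atoms are the same and only their arrangement on the pyrazole changes. For the measured compounds named here, the one measured step, a 63-fold lower number from compound 1 to compound 2 (1.80 log units; beyond the scatter), exchanged the whole acyl group for the pyrazole and so says nothing about a shift of the methyl within that ring. Going by the values given here, no measured pair compares two pyrazole isomers. With the amide, the pyrazole donor and acceptor and the core all retained, the expectation for compound 3 in this assay is a step of a 2.0-fold higher number from compound 2 to compound 3 (0.31 log units; beyond the scatter), likely within the scatter, with a wide range to allow for an unseen effect. The estimate for compound 3 is 250 nM, between 60 nM and 1500 nM.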

Compound 3, half-maximal effective concentration: 590 nM
For compound 3 the middle estimate is 2.4-fold (0.37 log units) below the measured one; the range from low to high includes it.
By their numbers in this assay, from the lowest: compound 2; then compound 3; then compound 1.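

Moving the methyl within the pyrazole is not a silent change in this assay: the exchange of 4-methyl-1H-pyrazol-5-yl for 3-methyl-1H-pyrazol-5-yl on the carbonyl carbon keeps the same atoms, with the same counts of hydrogen-bond donors and acceptors, yet it gives a 4.8-fold higher number from compound 2 to compound 3 (0.68 log units; beyond the scatter). The arrangement of the ring substituent therefore matters at this position, a point the exchange of the whole acyl group could not show. The 3-methyl-1H-pyrazol-5-yl group also stays well clear of 1-hydroxy-2,2-dimethylpropyl, with a 13-fold lower number from compound 1 to compound 3 (1.12 log units; beyond the scatter), so the advantage over that group does not depend on one methyl placement, and nothing at hand explains the difference between the two isomers.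

Still open, going by these compounds, is whether the methyl itself contributes, which a pyrazole without it would address, and whether a larger group such as ethyl or a halogen such as chlorine on 1H-pyrazol-5-yl would follow the same order. Also open, on these data alone, is how far the pyrazole can be replaced, for example by an imidazole or a 1-methylpyrazole lacking the ring hydrogen on nitrogen.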